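Two Chlorines on the Outer Phenyl Ring

This account rests on a few compounds, and the source may have more. Where it says the series, first, only, none or still open, it means among the compounds named here.

Going by the values given here, compound 2 `COc1ccc(Cl)cc1-n1ncc(-c2nnc(-c3ccccc3)o2)c1C` is the lower of the two compounds measured so far in a physicochemical assay for lipophilicity, using the shake flask method, measured as octanol-water partition; on this read-out higher numbers stand for higher lipophilicity and lower numbers for lower lipophilicity: compound 2 gives 4.32, while compound 1 `COc1ccc(Cl)cc1-n1ncc(-c2nnc(-c3ccc(Br)c(C)c3)o2)c1C` gives 5.2. Among the compounds with values here, the one measured step, a number 0.88 log units lower from compound 1 to compound 2 (beyond the scatter), shows a modest drop when the substituted outer ring is replaced by plain phenyl. Compound 3 `COc1ccc(Cl)cc1-n1ncc(-c2nnc(-c3ccc(Cl)c(Cl)c3)o2)c1C` is not yet measured. It differs from compound 2 in one place: 3,4-dichlorophenyl in place of phenyl on an aromatic carbon. This change is the reverse kind of move to the measured step, going from plain phenyl to a substituted ring, so a rise in this assay beyond the scatter is expected, roughly of the size of the measured step or somewhat larger. Compound 3 is therefore expected to give about 5.4, in a range from 4.9 to 5.9. The expected step, a number 1.08 log units higher from compound 2 to compound 3 (beyond the scatter), is an estimate resting only on compound 1 with 5.2 and compound 2 with 4.32.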

Compound 3, partition coefficient: 5.57
Beside the measured number, compound 3's estimate is 0.17 log units below it; low and high end bracket the measured number.
By their numbers in this assay, from the lowest: compound 2; then compound 1; then compound 3.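

In this assay, this position on the ring with two nitrogens and one oxygen now has two substituted outer rings to compare with plain phenyl, and 3,4-dichlorophenyl gives a number 1.25 log units higher from compound 2 to compound 3 (beyond the scatter), a large step. The two substituted rings also differ from each other, with a number 0.37 log units higher from compound 1 to compound 3 (beyond the scatter), so among these three compounds the number depends on which groups the outer ring carries and not only on whether it carries any. Nothing available here explains why the number moves in this way.

The compounds shown leave open how much of the large step a single chlorine on the outer ring would give. They also leave open where the number would fall with an amine or a carboxylic acid on that ring.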